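This account rests on a few compounds, and the source may have more. Where it says the series, first, only, none or still open, it means among the compounds named here.

Measured in a functional assay on DU-145 cells (Homo sapiens) for inhibition; on this read-out higher numbers stand for weaker inhibition and lower numbers for stronger inhibition:
- Compound 1 `CCOc1ccc(Cl)cc1-c1cc(Nc2ccc(Cl)cc2)nc(N)n1`: 70 nM
- Compound 2 `CCOc1ccc(Cl)cc1-c1cc(Nc2ccc([N+](=O)[O-])cc2)nc(N)n1`: 350 nM
- Compound 3 `CCOc1ccc(Cl)cc1-c1cc(Nc2cccc([N+](=O)[O-])c2)nc(N)n1`: > 1000 nM

All three compounds share one core and differ only in the aryl group on a nitrogen. Compound 3 gives > 1000 nM in this assay, and this is a limit of the assay, not a number. As far as these compounds go, compound 3 therefore has the highest reading of the three, although its true value is unknown.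

The next compound, compound 4 `CCOc1ccc(Cl)cc1-c1cc(Nc2ccc3c[nH]nc3c2)nc(N)n1`, has not yet been measured. It carries 2H-indazol-6-yl in place of 3-nitrophenyl on a nitrogen on an aromatic ring.

Three measured steps change this same group. They are a 5.0-fold higher number from compound 1 to compound 2 (0.70 log units; beyond the scatter), an at least 14-fold higher number from compound 1 to compound 3 (1.15 log units; beyond the scatter) and an at least 2.8-fold higher number from compound 2 to compound 3 (0.45 log units; beyond the scatter), ranging from modest to large. Going by the values given here, this shows that the reading responds clearly to changes in this group, but no measured compound carries 2H-indazol-6-yl, so the size of the new step remains uncertain.

Compound 1 at 70 nM and compound 2 at 350 nM both show that other aryl groups on this core can give lower readings than compound 3, so a lower number is expected. The expected change is an at least 3.3-fold lower number from compound 3 to compound 4 (0.52 log units; beyond the scatter), a modest to large move towards stronger inhibition.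

For compound 4 the estimate is 300 nM, with an expected range from 70 nM to 1300 nM.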

Compound 4, half-maximal inhibitory concentration: 200 nM
Estimate against measurement, compound 4: 1.5-fold (0.18 log units) above; the range from low to high includes it.
By their numbers in this assay, from the lowest: compound 1; then compounds 4 and 2 (each within the scatter of the next). At a limit, above all of these: compound 3.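

Replacing 3-nitrophenyl with the larger two-ring 2H-indazol-6-yl restores clear inhibition in this assay, giving an at least 5.0-fold lower number from compound 3 to compound 4 (0.69 log units; beyond the scatter), so this nitrogen substituent need not be a single six-membered ring. That step can be given only as a minimum because compound 3, at > 1000 nM, stands at a limit of the assay and not at a number: the limit of > 1000 nM in this assay, at which 1 of the 4 values shown sits.

Against the two para-free comparisons that have real numbers, the new group gives a 1.8-fold lower number from compound 2 to compound 4 (0.24 log units; within the scatter), which is within the scatter and does not separate it from 4-nitrophenyl, while a 2.9-fold higher number from compound 1 to compound 4 (0.46 log units; beyond the scatter) leaves it short of 4-chlorophenyl, which still has the lowest reading of the compounds shown.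

The compounds shown do not separate the contribution of the five-membered ring in 2H-indazol-6-yl from that of its hydrogen-bond donor, as both enter in the same change. They also leave open how a phenyl ring carrying an amine or a methoxy group, or a related two-ring group such as indol-6-yl, would read on this core.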